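A few compounds are considered here, and "the series" means these few. Any claim that something is new, unique, unknown or untested is made for them only; others in the source may bear on it.

In a functional assay on HeLa cells (Homo sapiens) for antiproliferative activity, read by MTT assay, with a stated time of 24 h (a higher number here means a weaker inhibitor, a lower number a stronger inhibitor), compound 1 `Clc1ccccc1CSc1nnc(-c2ccc3c(c2)OCCO3)n1-c1ccccc1` gives 29000 nM while compound 2 `Cc1ccccc1CSc1nnc(-c2ccc3c(c2)OCCO3)n1-c1ccccc1` gives 36000 nM and compound 3 `Cc1ccc(CSc2nnc(-c3ccc4c(c3)OCCO4)n2-c2ccccc2)cc1` gives 49700 nM as its value. Compound 3 thus lies within the scatter of both others, and no order among the three can be drawn. Compound 4 `Brc1cccc(CSc2nnc(-c3ccc4c(c3)OCCO4)n2-c2ccccc2)c1` differs from compound 3 in one place 3-bromophenyl in place of 4-methylphenyl on a saturated chain carbon bound to a sulfur and carries 3-bromophenyl in place of 4-methylphenyl on a saturated chain carbon bound to a sulfur. Two measured steps change the group at that place, a 1.4-fold higher number from compound 2 to compound 3 (0.14 log units; within the scatter) and a 1.7-fold higher number from compound 1 to compound 3 (0.23 log units; within the scatter) and a third, a 1.2-fold higher number from compound 1 to compound 2 (0.09 log units; within the scatter) puts methyl in place of chloro on an aromatic carbon. Among the measured compounds shown here, no bromo compound has been measured. No step beyond the scatter is therefore expected in this assay here. The expected step is a 1.3-fold lower number from compound 3 to compound 4 (0.12 log units; within the scatter) and no direction can be relied on. For compound 4 the estimated value is 38000 nM with an expected range from 18000 nM to 75000 nM in this measure.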

Compound 4, half-maximal inhibitory concentration: 44200 nM
The estimate for compound 4 lay 1.2-fold (0.07 log units) below the measured number; the range from low to high includes it.
By their numbers in this assay, from the lowest: compounds 1, 2, 4 and 3 (each within the scatter of the next).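

In this assay, 3-bromophenyl on a saturated chain carbon bound to a sulfur gives three steps, all within the scatter: (a 1.1-fold lower number from compound 3 to compound 4 (0.05 log units; within the scatter)), (a 1.2-fold higher number from compound 2 to compound 4 (0.09 log units; within the scatter)) and (a 1.5-fold higher number from compound 1 to compound 4 (0.18 log units; within the scatter)). A bromine-bearing ring at this place thus stands with the chloro and methyl rings, and no order among the four compounds can be drawn. Nothing measured here offers an explanation for this result. The compounds shown leave open whether an amine, a carboxylic acid or a longer chain at this place would give a step beyond the scatter.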